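A few compounds are considered here, and "the series" means these few. Any claim that something is new, unique, unknown or untested is made for them only; others in the source may bear on it.

Measured so far:
- compound 1 `COc1cc(C(=O)O)ccc1OCCCCOc1ccc(C(=O)CC(C)C)c(O)c1C`: 43%
- compound 2 `Cc1c(OCCCCOc2cccc(C(=O)O)c2)ccc(C(=O)CC(C)C)c1C`: 29%
- compound 3 `Cc1c(OCCCCOc2ccccc2C(=O)O)ccc(C(=O)CC(C)C)c1C`: 9%

In an ADME assay (liver) for metabolic stability, with Liver microsome (Rattus norvegicus) as the target, read by LC-MS, using microsomes and NADPH, with stated times of 5 min and 60 min, tested at 4 uM (a higher number here means that more of the compound is left, a lower number that less of the compound is left), compound 2 gives 29%, the middle number of the three. Compound 1 stands higher, beyond the usual scatter, and compound 3 stands lower, also beyond it.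

Compound 4 `Cc1c(OCCCCOc2cccc(C(=O)O)c2)ccc(C(=O)CC(C)C)c1O` has not been measured yet. It differs from compound 2 by a single change: hydroxy in place of methyl on an aromatic carbon. Here hydroxy takes the place of methyl on an aromatic carbon, ortho to a methyl group and ortho to an isobutylcarbonyl group.

For the measured compounds named here, the only measured single change is a number 20 percentage points lower from compound 2 to compound 3 (beyond the scatter). It concerns the carboxyphenyl group, not this swap, so it shows only how far one change has moved this assay within this small set. Compound 1, at 43%, also carries a hydroxy group in that place. It differs from compound 2 in other places too, which makes it a loose hint of an upward move and no proof of one.

The expected change is a number 8 percentage points higher from compound 2 to compound 4 (within the scatter), a modest rise that may stay within the scatter. For compound 4 the estimated value is 37%, with an expected range of 20% to 55%.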

Compound 4, percent of the compound remaining: 51%
For compound 4 the middle estimate is 14 percentage points below the measured one, within the range that was stated.
By their numbers in this assay, from the lowest: compound 3; then compound 2; then compounds 1 and 4 (each within the scatter of the next).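

In this assay, the swap of methyl for hydroxy, on the aromatic carbon ortho to a methyl group and ortho to an isobutylcarbonyl group, gives a number 22 percentage points higher from compound 2 to compound 4 (beyond the scatter) and so lies beyond the scatter. This shows that the position matters to how much compound is left, since a change of one heavy atom moves the number while the rest of the molecule stays the same. The only single change read before, a number 20 percentage points lower from compound 2 to compound 3 (beyond the scatter), lay in the carboxyphenyl group and went down, so this is the first single change shown to go up, and the first read at this position; nothing measured here bears on what lies behind the rise.

Among the compounds shown, this position carries only methyl or hydroxy, so it stays open whether the rise follows from gaining the hydroxy or from losing the methyl, a question that a methoxy, an amine or a plain hydrogen at the same place could help to settle. On these data alone, it also stays open whether the same swap would raise the number of compound 3, with its 2-carboxyphenyl group.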